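The source may hold more compounds than are shown below. What is called first, only, known or untested is meant among the compounds shown, and "the series" means these compounds.

Compound 1, `COc1cc2ncnc(NNC(=S)NC(=O)c3ccc(Cl)cc3)c2cc1OC`: 8940 nM
Compound 2, `COc1ccccc1C(=O)NC(=S)NNc1ncnc2ccccc12`: 8700 nM

Both compounds were tested in a functional assay on MCF7 cells (Homo sapiens) for cytotoxicity, read by MTT assay, with a stated time of 72 h; on this read-out lower numbers stand for stronger inhibition and higher numbers for weaker inhibition. On those two numbers compound 1 and compound 2 lie within the scatter of each other, so neither can be set above the other; compound 1 simply shares the weak end of the small set with compound 2.

Compound 3, `COc1cc2ncnc(NNC(=S)NC(=O)c3ccc(C(F)(F)F)cc3)c2cc1OC`, is not yet measured. It is built from compound 1 by one change: trifluoromethyl in place of chloro on an aromatic carbon. For the measured compounds named here, no measured pair in this set shows a change of this kind, so there is nothing in the numbers to anchor how large its effect might be. The expectation is a step from compound 1 to compound 3 that stays within the scatter of this assay, a 1.1-fold lower number from compound 1 to compound 3 (0.05 log units; within the scatter). Compound 3 is therefore estimated to give about 8000 nM in this assay. Its expected range runs from 3000 nM to 22000 nM.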

Compound 3, half-maximal inhibitory concentration: 16800 nM
Compound 3: middle estimate off by 2.1-fold (0.32 log units), on the low side; low and high end bracket the measured number.
By their numbers in this assay, from the lowest: compounds 2, 1 and 3 (each within the scatter of the next).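

For the compounds shown here, this step gives the first reading of what a change on the 4-chlorophenyl ring does. In this assay, putting trifluoromethyl, with four heavy atoms, in place of chloro, with one, gives a 1.9-fold higher number from compound 1 to compound 3 (0.27 log units; within the scatter) and so compound 1 and compound 3 cannot be told apart. At this place, then, the larger of these two groups brings no step beyond the scatter, and no measurement at hand offers an explanation for this result.

Chloro and trifluoromethyl both count no hydrogen-bond donors, no hydrogen-bond acceptors and no net charge, so it stays open whether an amine or a carboxylic acid at this place would shift the number beyond the scatter. Also open, as far as these compounds go, is whether the same swap would read alike on a different core.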